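Working notes: amide aryl change, compound 2 to compound 3

A few compounds are considered here, and "the series" means these few. Any claim that something is new, unique, unknown or untested is made for them only; others in the source may bear on it.

Compound 1 `COc1cc(F)c(NC(=O)c2ccnc(Cl)c2)cc1Nc1nccc(-c2cn(C)c3ccccc23)n1` and compound 2 `COc1ccc(C(=O)Nc2cc(Nc3nccc(-c4cn(C)c5ccccc45)n3)c(OC)cc2F)nc1` share the same core and differ only in the aryl group attached to the amide carbonyl carbon. In a functional assay on A549 cells (Homo sapiens) for antiproliferative activity, read by MTT assay, with a stated time of 72 h (on this read-out lower numbers stand for stronger inhibition and higher numbers for weaker inhibition), compound 1 gives 6890 nM and compound 2 gives 8200 nM. Going by the values given here, compound 2 holds the higher of the two numbers measured so far, but the step of a 1.2-fold higher number from compound 1 to compound 2 (0.08 log units; within the scatter) lies within the scatter, so no order between the two can be claimed.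

Compound 3 `COc1cc(F)c(NC(=O)c2ncccn2)cc1Nc1nccc(-c2cn(C)c3ccccc23)n1` has not yet been measured. It differs from compound 2 by pyrimidin-2-yl in place of 5-methoxypyridin-2-yl on a carbonyl carbon. Among the compounds with values here, the only measured step that bears on this change, a 1.2-fold higher number from compound 1 to compound 2 (0.08 log units; within the scatter), also exchanged the aryl group on the carbonyl carbon and stayed within the scatter. On that single step, no change beyond the scatter is expected for compound 3 in this assay, in either direction. The step expected from this change is a 1.2-fold lower number from compound 2 to compound 3 (0.07 log units; within the scatter). The estimate for compound 3 in this assay is 7000 nM, with a range from 2500 nM to 20000 nM.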

Compound 3, half-maximal inhibitory concentration: 8400 nM
Beside the measured number, compound 3's estimate is 1.2-fold (0.08 log units) below it; measured number inside the range.
By their numbers in this assay, from the lowest: compounds 1, 2 and 3 (each within the scatter of the next).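

Working notes, continued: in this assay the aryl group on the carbonyl carbon has now been exchanged again, and both a 1.0-fold higher number from compound 2 to compound 3 (0.01 log units; within the scatter) and a 1.2-fold higher number from compound 1 to compound 3 (0.09 log units; within the scatter) lie within the scatter, so no order can be drawn among the three compounds. The step from compound 2 to compound 3 is also a larger exchange than the earlier pair alone offered: 5-methoxypyridin-2-yl with 8 heavy atoms and one ring hetero atom gives way to pyrimidin-2-yl with 6 heavy atoms and two ring hetero atoms, and this loss of the methoxy group and gain of a ring nitrogen still yields no difference beyond the scatter. No evidence at hand bears on this result.

From the compounds shown here alone, all three groups on the carbonyl carbon are six-membered aromatic rings containing nitrogen, so it remains open whether a different kind of group there, such as a piperidine, a carboxylic acid or a longer alkyl chain, would give a step beyond the scatter. Also open, going by these compounds, is whether changes elsewhere on the shared core would behave in the same way.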